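Swapping Dihydroxyphenyl for Dichlorophenyl on the Shared Core

A few compounds are considered here, and "the series" means these few. Any claim that something is new, unique, unknown or untested is made for them only; others in the source may bear on it.

Compound 2 `Cn1cnc2c(N3CCCCC3)nc(-c3cccc(O)c3O)nc21` stands highest of the two plain numbers in an assay on cells for displacement of a labelled ligand from adenosine receptor A3 (Homo sapiens), read by scintillation counting and radioligand binding, with a stated time of 180 min, tested at 10 uM (a higher number here means more inhibition at the concentration tested (going by the name of the read-out), a lower number less inhibition), where compound 2 gives 33.7%. Compound 1 `Cn1cnc2c(N3CCCCC3)nc(-c3ccccc3O)nc21` gives 20% in this assay. For the measured compounds named here, the only measured step is a number 13.7 percentage points higher from compound 1 to compound 2 (beyond the scatter). Compound 3 `Clc1ccc(-c2nc(N3CCCCC3)c3nc[nH]c3n2)cc1Cl` reaches only a limit of this assay, > 80%, which is the limit of > 80% in this assay, at which 1 of the 3 values shown sits. Compound 4 `Cn1cnc2c(N3CCCCC3)nc(-c3cc(Cl)ccc3Cl)nc21` differs from compound 2 by 2,5-dichlorophenyl in place of 2,3-dihydroxyphenyl on an aromatic carbon. The measured step concerns a hydroxy group, so it bears on this exchange only loosely; compound 3 also carries a dichlorophenyl, though on a differently substituted core, and sits at the limit. An increase in this assay is therefore expected, though its size is uncertain. Compound 4 is estimated at 55%, between 25% and 85%, an expected step of a number 21.3 percentage points higher from compound 2 to compound 4 (beyond the scatter).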

Compound 4, a percentage reported as inhibition, at one concentration (the size of the read-out at that concentration, not a potency): 5.4%
Compound 4: the middle estimate sits 49.6 percentage points above what was measured; the whole stated range lies above it.
By their numbers in this assay, from the lowest: compound 4; then compound 1; then compound 2. At a limit, above all of these: compound 3.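

At this position on the shared core, putting 2,5-dichlorophenyl in place of the hydroxy-bearing rings gives a number 28.3 percentage points lower from compound 2 to compound 4 (beyond the scatter) and also a number 14.6 percentage points lower from compound 1 to compound 4 (beyond the scatter) in this assay. Both hydroxy-bearing phenyl groups therefore read higher here than the chlorine-bearing one. Nothing measured here accounts for this drop. The compounds shown leave open whether a methoxy group or an amine on the phenyl ring would keep the higher numbers. They also leave open whether the result for the dichlorophenyl group depends on where its two chlorines sit.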